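Working notes: chloro for hydrogen, compound 2 to compound 3

The source may report more compounds than this note shows. Statements on the series, on what has been measured and on what is new or still open speak of the compounds shown alone.

Measured so far:
compound 1 `CC(C)n1cnc2c(Nc3cccc(Cl)c3)nc(NCOCc3ccc(C(=O)Nc4ccccc4N)cc3)nc21`, in a functional assay on NCI-H460 cells (Homo sapiens) for antiproliferative activity, read by CCK-8 assay, with a stated time of 72 h, tested at 8 uM (a higher number here means a stronger effect of the compound at the concentration tested, a lower number a weaker effect), compound 1 gives 43.2%
compound 2 `Nc1ccccc1NC(=O)c1ccc(COCNc2nc(Nc3ccccc3)c3ncn(C4CCCC4)c3n2)cc1`, in this assay compound 2 gives 56.1%

Compound 2 stands highest of the two numbers; its nearest neighbour is compound 1, whose inhibition is lower by a margin beyond the usual scatter. Among the compounds with values here, the two differ in more than one place, so no single step between them is counted.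

Compound 3 `Nc1ccccc1NC(=O)c1ccc(COCNc2nc(Nc3cccc(Cl)c3)c3ncn(C4CCCC4)c3n2)cc1` is not yet measured. It departs from compound 2 by chloro in place of hydrogen on an aromatic carbon. Within the data shown here, the only other compound that carries this chloro is compound 1, which also differs in its core substituent, so no clean precedent exists.

For this assay the step of a number 6.1 percentage points lower from compound 2 to compound 3 (within the scatter) is expected to be small and, if anything, downward, staying within or near the scatter. Compound 3 is therefore estimated at 50%, between 35% and 65%.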

Compound 3, a percentage reported as inhibition, at one concentration (the size of the read-out at that concentration, not a potency): 49.2%
Compound 3: middle estimate off by 0.8 percentage points, on the high side; the measured number falls inside the stated range.
By their numbers in this assay, from the lowest: compounds 1, 3 and 2 (each within the scatter of the next, the first and the last beyond it).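

In this assay, within the data shown here, chloro in place of hydrogen on an aromatic carbon, phenyl to 3-chlorophenyl, gives a number 6.9 percentage points lower from compound 2 to compound 3 (within the scatter) and is the first single-place reading at this position: at this concentration, the two groups are not told apart. Cyclopentyl in place of isopropyl on an aromatic nitrogen gives a number 6 percentage points higher from compound 1 to compound 3 (within the scatter) with the 3-chlorophenyl group held constant, so this second single change is not resolved either. No measurement here bears on the reason for the size of either step.

Going by these compounds, whether another group on this ring carbon, such as methoxy, an amine or a carboxylic acid, would give a step beyond the scatter remains open. Also open, on these data alone, is how a longer chain such as n-hexyl on the aromatic nitrogen would read in this assay on the same scaffold.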